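Adding a Fluorine to Compound 2: What to Expect

This account rests on a few compounds, and the source may have more. Where it says the series, first, only, none or still open, it means among the compounds named here.

Of the compounds shown here, three sharing one core have been measured. In a functional assay on A549 cells (Homo sapiens) for inhibition, read by MTT assay, with a stated time of 72 h (a lower number here means a stronger inhibitor, a higher number a weaker inhibitor), compound 1 `O=C(Nc1ccc(Oc2ccnc3[nH]ccc23)cc1)c1cn(-c2ccccc2)c2ccccc2c1=O` gives 1030 nM. Compound 2 `O=C(Nc1ccc(Oc2ccnc3[nH]ccc23)cc1)c1cn(-c2ccc(Cl)cc2)c2ccccc2c1=O` gives 650 nM, the lowest number of the three, though compound 1 sits close by, since a 1.6-fold lower number from compound 1 to compound 2 (0.20 log units; within the scatter). Compound 3 `COc1ccc(-n2cc(C(=O)Nc3ccc(Oc4ccnc5[nH]ccc45)cc3)c(=O)c3ccccc32)cc1` gives 4980 nM, and both a 4.8-fold higher number from compound 1 to compound 3 (0.68 log units; beyond the scatter) and a 7.7-fold higher number from compound 2 to compound 3 (0.88 log units; beyond the scatter).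

Compound 4 `O=C(Nc1ccc(Oc2ccnc3[nH]ccc23)c(F)c1)c1cn(-c2ccc(Cl)cc2)c2ccccc2c1=O` has not yet been measured. It differs from compound 2 in one place: fluoro in place of hydrogen on an aromatic carbon. Within the data shown here, no measured step tests a fluoro group, and none touches this ring of the core; the single halogen step seen so far, from compound 1 to compound 2 on another ring, stayed within the scatter. A single fluorine is the smallest substituent that can be added, so a step in this assay is expected to be small, in either direction, or none beyond the scatter.

Compound 4 is therefore estimated at 600 nM, with a range from 300 nM to 1300 nM. The step expected from compound 2 is a 1.1-fold lower number from compound 2 to compound 4 (0.03 log units; within the scatter).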

Compound 4, half-maximal inhibitory concentration: 320 nM
Compound 4: middle estimate off by 1.9-fold (0.27 log units), on the high side; the measured number falls inside the stated range.
By their numbers in this assay, from the lowest: compound 4; then compounds 2 and 1 (each within the scatter of the next); then compound 3.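

This is the first change shown on this ring of the shared core: in this assay, fluoro in place of hydrogen, on an aromatic carbon ortho to a large group and meta to a large group, gives a 2.0-fold lower number from compound 2 to compound 4 (0.31 log units; beyond the scatter). The position therefore responds to substitution, and a single added fluorine, just one heavy atom, can move the number beyond the scatter, though only modestly. Nothing available here accounts for the shift.

The compounds shown carry only hydrogen and fluoro at this position, so it remains open whether a chloro, a methoxy, a nitrile or an amine there would lower the number further or raise it. Also open, going by these compounds, is whether the same fluoro would give a similar step when added to compound 1 or compound 3.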